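Changing the Aryl Group of Compound 3: A Permeability Outlook

This account rests on a few compounds, and the source may have more. Where it says the series, first, only, none or still open, it means among the compounds named here.

Compound 1 `Cc1ccccc1-c1nc(CN2CCC(C(=O)NCCCN3[C@H](C)CCC[C@@H]3C)CC2)c(C)o1` gives 55.4 10^-6 cm/s in a physicochemical assay for permeability, using PAMPA; a lower number here means that the compound crosses the layer more slowly, a higher number that the compound crosses the layer faster.
Compound 2 `Cc1ccccc1-c1nc(CN2CCC(C(=O)NCCCN3CCCC(C(C)C)C3)CC2)c(C)o1` gives "not determined" (no result reported) in this assay.
Compound 3 `Cc1oc(-c2c(Cl)cccc2Br)nc1CN1CCC(C(=O)NCCCN2C[C@H](C)C[C@H](C)C2)CC1` gives "not determined" (no result reported) in this assay.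

Within the data shown here, three compounds have been examined, but only compound 1 has a numerical result: the other two, including compound 3, were not determined, so compound 3 stands without a number of its own and there is no measured step from it to any other compound. Compound 1 is therefore the only reference point for how fast members of this series cross the layer.

Compound 4 `COc1ccc(-c2nc(CN3CCC(C(=O)NCCCN4C[C@H](C)C[C@H](C)C4)CC3)c(C)o2)cc1OC` differs from compound 3 in a single place: 3,4-dimethoxyphenyl in place of 2-bromo-6-chlorophenyl on an aromatic carbon. Since no step between measured compounds is shown, the size and direction of the change cannot be read off from the data. What remains is the value of compound 1 as a rough guide, and the expectation that a change of a single aryl group will shift the read-out by an amount that may or may not exceed the usual scatter. On that basis, compound 4 is estimated at 30 10^-6 cm/s in this assay, with a plausible range from 10 10^-6 cm/s to 80 10^-6 cm/s.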

Compound 4, apparent permeability: 81.9 10^-6 cm/s
Compound 4: the middle estimate sits 2.7-fold (0.44 log units) below what was measured; measured number outside the range, above it.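

Among these compounds, compound 4 gives 81.9 10^-6 cm/s in this assay, but compound 3 has no single number in this assay, so no step between compound 3 and compound 4 can be read. The compounds shown leave open how replacing 2-bromo-6-chlorophenyl with 3,4-dimethoxyphenyl shifts this read-out. Nothing shown bears on the reason for the result of compound 4.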